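Aryl thioether benzamide series: growth inhibition working notes

This account rests on a few compounds, and the source may have more. Where it says the series, first, only, none or still open, it means among the compounds named here.

Measured so far:
compound 1, `Nc1ccccc1NC(=O)/C=C/c1ccc(CSc2ccc(F)cc2)cc1`; in a functional assay on A-375 cells (Homo sapiens) for inhibition, read by CCK-8 assay, with a stated time of 72 h, tested at 2 uM (a higher number here means more inhibition of growth at the concentration tested, a lower number less inhibition of growth), compound 1 gives 28.8%.
compound 2, `COc1ccc(SCc2ccc(C(=O)Nc3ccccc3N)cc2)cc1`; in this assay compound 2 gives 10.2%.

Compound 1 stands highest of the two numbers. Its nearest neighbour is compound 2, whose value lies lower by a gap beyond the usual scatter. Within the data shown here, no two measured compounds differ in a single place, so the weight of any one structural change cannot be read from these two alone.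

Compound 3, `CC(C)(C)c1ccc(SCc2ccc(/C=C/C(=O)Nc3ccccc3N)cc2)cc1`, has not yet been measured. It differs from compound 1 in one place: tert-butyl in place of fluoro on an aromatic carbon. Among the measured compounds shown here, nothing measured so far speaks directly to this change, so a small step in either direction, or none beyond the scatter, is what is expected; the expected step is a number 3.2 percentage points higher from compound 1 to compound 3 (within the scatter). Compound 3 is estimated at 32%, with a range from 14% to 52%.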

Compound 3, percent growth inhibition at one concentration: 38.4%
Compound 3: middle estimate off by 6.4 percentage points, on the low side; low and high end bracket the measured number.
By their numbers in this assay, from the lowest: compound 2; then compounds 1 and 3 (each within the scatter of the next).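

In this assay, among these compounds, the change from 4-fluorophenyl to 4-(tert-butyl)phenyl gives the first single-place comparison: a number 9.6 percentage points higher from compound 1 to compound 3 (within the scatter), so these two compounds cannot be placed in an order. At this aromatic carbon, para to a large group, tert-butyl with its 4 heavy atoms can stand in place of fluoro with no difference beyond the scatter. No data are at hand to explain this result.

On these data alone, whether the same holds for an amine or a carboxylic acid at this position remains open, since fluoro and tert-butyl both carry no hydrogen-bond donors or acceptors and no net charge. Compound 2 differs from compound 1 and compound 3 in more than one place, so no single-place step can be read from it.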